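The compounds below may be only part of what the source reports. "The series", "measured", "known", "first", "only" and "open" are said of these compounds alone.

Compound 1 `Cc1ccccc1-c1nc(CN2CCC(C(=O)NCCCN3CCC(C)(C)CC3)CC2)c(C)o1`: 241 10^-6 cm/s.
Compound 2 `Cc1oc(-c2ccc(F)cc2)nc1CN1CCC(C(=O)NCCCN2C[C@H](C)C[C@H](C)C2)CC1`: "not determined" (no result reported).
Compound 3 `Cc1ccccc1-c1nc(CN2CCC(C(=O)NCCCN3CCCC(C(C)C)C3)CC2)c(C)o1`: "not determined" (no result reported).

In a physicochemical assay for permeability, using PAMPA (a higher number here means that the compound crosses the layer faster, a lower number that the compound crosses the layer more slowly), compound 1 gives 241 10^-6 cm/s. For compound 2 the entry in this assay is "not determined" (no result reported), and for compound 3 it is "not determined" (no result reported), so compound 2 stands without any value of its own to compare against.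

Compound 4 `CCc1ccccc1-c1nc(CN2CCC(C(=O)NCCCN3C[C@H](C)C[C@H](C)C3)CC2)c(C)o1` differs from compound 2 in one place: 2-ethylphenyl in place of 4-fluorophenyl on an aromatic carbon. For the measured compounds named here, with no measured step available, the expectation rests on compound 1 alone, which shares most of its structure with compound 4. Compound 4 is therefore expected to cross the layer at a rate close to that of compound 1, because compound 1 gives 241 10^-6 cm/s in this assay. The estimate for compound 4 is 250 10^-6 cm/s, with a range from 120 10^-6 cm/s to 500 10^-6 cm/s.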

Compound 4, apparent permeability: 106 10^-6 cm/s
For compound 4 the middle estimate is 2.4-fold (0.37 log units) above the measured one; the whole stated range lies above it.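

For the compounds shown here, compound 2 has no single number in this assay and so no step to compound 4 can be read. What replacing 4-fluorophenyl with 2-ethylphenyl does to the crossing rate stays open, and nothing shown here offers an explanation for the result.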